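Swapping the aryl ether on a peptidic ketone scaffold

The source may hold more compounds than are shown below. What is called first, only, known or untested is meant among the compounds shown, and "the series" means these compounds.

Measured compounds:
compound 1 `CC(C)[C@H](NC(=O)COc1cccc2ccccc12)C(=O)N[C@@H](CC(=O)O)C(=O)COc1ccc2ccccc2c1` gives 15900 nM
compound 2 `CC(C)[C@H](NC(=O)COc1cccc2ccccc12)C(=O)N[C@@H](CC(=O)O)C(=O)COc1ccc(Oc2ccccc2)cc1` gives 19000 nM

Both were tested in a functional assay with Homo sapiens as the target; on this read-out higher numbers stand for weaker inhibition and lower numbers for stronger inhibition. Compound 1 has the lowest of the two numbers; compound 2 sits so close to it that the two values fall within the usual scatter of repeated measurements, so nothing can be said about an order between them. Both compounds share the same core and differ only in the aromatic group carried on the oxygen at the end of the chain.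

Compound 3 `CC(C)[C@H](NC(=O)COc1cccc2ccccc12)C(=O)N[C@@H](CC(=O)O)C(=O)COc1ccccc1[N+](=O)[O-]` is not yet measured. Relative to compound 1 the change is 2-nitrophenyl in place of naphthalen-2-yl on an oxygen on a saturated carbon. Cut one bond further out, the naphthalen-2-yl oxy group becomes a 2-nitrophenoxy group, and the ring system that leaves is replaced by a single ring carrying a nitro group.

For the measured compounds named here, no step between measured compounds is available for this position. With compound 1 and compound 2 sitting together despite quite different aromatic groups at this place, the expectation is a step from compound 1 to compound 3 of about a 1.3-fold higher number from compound 1 to compound 3 (0.10 log units; within the scatter), with no clear direction beyond the scatter. Compound 3 is therefore estimated at 20000 nM, with a range from 6000 nM to 65000 nM.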

Compound 3, half-maximal inhibitory concentration: 27700 nM
Beside the measured number, compound 3's estimate is 1.4-fold (0.14 log units) below it, and the stated range covers the measured number.
By their numbers in this assay, from the lowest: compounds 1, 2 and 3 (each within the scatter of the next).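

In this assay, putting 2-nitrophenyl in place of naphthalen-2-yl on this oxygen gives a 1.7-fold higher number from compound 1 to compound 3 (0.24 log units; within the scatter). The position has now held a group with a single aromatic ring, nitrogen and oxygen atoms and two hydrogen-bond acceptors, and the step from the all-carbon, two-ring naphthalen-2-yl, which has no hydrogen-bond acceptors, still does not leave the scatter. So neither losing the second ring while adding the nitro group nor the change in acceptor count, taken together as they come in this one swap, shows up as a readable difference on this read-out, and nothing measured here offers an explanation for the numbers.

Going by these compounds, because the second ring and the nitro group change together, their separate contributions stay unknown, and a plain phenyl group would be the compound that pulls them apart. On these data alone, it also remains open whether an amine or a carboxylic acid on the ring at this place, or a group that is not aromatic at all, such as a short alkyl chain, would move the number beyond the scatter in either direction.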